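Pyrrolidin-3-yl for cyclopropylmethyl: an expected tolerance step

A few compounds are considered here, and "the series" means these few. Any claim that something is new, unique, unknown or untested is made for them only; others in the source may bear on it.

Measured compounds in an ADME assay on THP-1 cells (Homo sapiens) for cytotoxicity; a lower number here means that less compound is tolerated, a higher number that more compound is tolerated:
Compound 1, `Cc1ccc2nc(-c3ccc(N(C)C)cc3)c(NC3CCCCC3)n2c1`, gives > 50000 nM, which is a limit of the assay and not a number.
Compound 2, `c1ccc(-c2nc3ccccn3c2NCC2CC2)nc1`, gives 19400 nM.

For the measured compounds named here, compound 2 holds the only actual number measured in this assay; the other entry is a limit. Compound 1 sits at the limit of > 50000 nM in this assay, at which 1 of the 2 values shown sits. Going by the values given here, the two compounds differ in more than one place, so no step between them is recorded, and their two values show only that compound 1 was tolerated up to the limit while compound 2 has a finite half-maximal cytotoxic concentration.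

Compound 3, `c1ccc(-c2nc3ccccn3c2NC2CCNC2)nc1`, differs from compound 2 by pyrrolidin-3-yl in place of cyclopropylmethyl on a nitrogen on an aromatic ring. Among the compounds with values here, no measured step informs this change, so the move expected in this assay is none beyond the scatter, with at most a slight lean toward more compound being tolerated. The step from compound 2 is expected to be a 1.3-fold higher number from compound 2 to compound 3 (0.11 log units; within the scatter). Compound 3 is therefore estimated at 25000 nM, with an expected range from 8000 nM to 80000 nM.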

Compound 3, half-maximal cytotoxic concentration: > 50000 nM
Compound 3: a limit, no number; the forecaster's own chance of this, stated with the estimate: 30%; middle value at least 2.0-fold (0.30 log units) away from the limit.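

In this assay, the change from cyclopropylmethyl to pyrrolidin-3-yl on a nitrogen on an aromatic ring now has a recorded size, the first step available at this position: an at least 2.5-fold higher number from compound 2 to compound 3 (0.41 log units; beyond the scatter). Compound 3 gives > 50000 nM, which is a limit of the assay and not a number. The step is therefore only a lower bound on the change, and how far the true value of compound 3 lies past that limit stays unknown, with the limit now the most common entry among the compounds shown: the limit of > 50000 nM in this assay, at which 2 of the 3 values shown sit.

The compounds shown leave open whether the step belongs to the nitrogen of pyrrolidin-3-yl or to the five-membered ring itself; a cyclopentyl group, with a five-membered ring of carbon only, or an open-chain aminoethyl group at the same place would separate the two. Also open, as far as these compounds go, is whether the same swap would give a step of similar size on the core of compound 1, and why the change has this effect on the cells, on which the data are silent.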